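This account rests on a few compounds, and the source may have more. Where it says the series, first, only, none or still open, it means among the compounds named here.

In a functional assay on SH-SY5Y cells (Homo sapiens) for antagonist activity, read by cAMP accumulation (a higher number here means a more potent compound, by a factor of ten per unit of this negative logarithm, a lower number a less potent compound), three compounds sharing one core have been measured, differing only in the group on an oxygen on an aromatic ring. Compound 1 `CC(C)Oc1ccc(Cc2ccc(NC3=NCCN3)cc2)cc1`, carrying isopropyl, gives 8.8. Compound 2 `CCCCCCOc1ccc(Cc2ccc(NC3=NCCN3)cc2)cc1`, carrying hexyl, gives 8.2, the second highest of the three numbers. Compound 3 `c1ccc(COc2ccc(Cc3ccc(NC4=NCCN4)cc3)cc2)cc1`, carrying benzyl, gives 7.7.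

The next structure is compound 4 `c1cc(NC2=NCCN2)ccc1Cc1ccc(OC2CCCC2)cc1`, with cyclopentyl in place of hexyl on an oxygen on an aromatic ring. For the measured compounds named here, no measured compound carries this ring, so the evidence is indirect. Going by the values given here, two steps bear on it most. Hexyl in place of isopropyl gave a number 0.60 log units lower from compound 1 to compound 2 (beyond the scatter), a modest step, and benzyl in place of isopropyl gave a number 1.10 log units lower from compound 1 to compound 3 (beyond the scatter), a large one. Among these three compounds, the smallest group goes with the highest number. Cyclopentyl is smaller than hexyl, so part of the first step may be recovered. The expected change is a modest rise, a number 0.40 log units higher from compound 2 to compound 4 (beyond the scatter). For compound 4 the estimate is 8.6, with an expected range from 8 to 9.1.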

Compound 4, negative logarithm of the antagonist equilibrium constant: 8.9
Compound 4: middle estimate off by 0.30 log units, on the low side, within the range that was stated.
By their numbers in this assay, from the lowest: compound 3; then compound 2; then compounds 1 and 4 (each within the scatter of the next).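

In this assay, the step of a number 0.70 log units higher from compound 2 to compound 4 (beyond the scatter) shows that the chain length or size of the group on this oxygen does not set the number alone: by the counts, cyclopentyl has 5 heavy atoms and hexyl 6, and the change also closes those carbons into a ring. A ring as such is not enough either, since benzyl also holds one and the step is a number 1.20 log units higher from compound 3 to compound 4 (beyond the scatter). The earlier pairing of the smallest group with the highest number now needs qualifying, as the larger cyclopentyl gives a number 0.10 log units higher from compound 1 to compound 4 (within the scatter), so the two compounds cannot be told apart here.

The compounds shown leave open whether a cyclobutyl, a cyclohexyl or a tetrahydropyranyl group on this oxygen would stay at this level. Nothing available explains the differences between these groups.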